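From phenyl to pyridin-2-yl at the limit

The compounds below may be only part of what the source reports. "The series", "measured", "known", "first", "only" and "open" are said of these compounds alone.

Compound 1 `OCC1CCN(c2nccnc2OC2CN(c3ccc4ccccc4n3)C2)C1`: 167000 nM
Compound 2 `NC(=O)C1CCN(c2nccnc2OC2CN(c3ccc4ccccc4n3)C2)CC1`: 14000 nM
Compound 3 `c1ccc(-c2nccnc2OC2CN(c3ccc4ccccc4n3)C2)cc1`: < 1000 nM (a limit)

All three compounds were read in a physicochemical assay for solubility, in phosphate buffer, at pH 7.4; on this read-out higher numbers stand for higher solubility and lower numbers for lower solubility. Compound 3 stands at < 1000 nM, which is a limit and not a number. Compound 4 `c1ccc(-c2nccnc2OC2CN(c3ccc4ccccc4n3)C2)nc1` differs from it by one change, pyridin-2-yl in place of phenyl on an aromatic carbon. Going by the values given here, two measured steps bear on this place, an at least 160-fold lower number from compound 1 to compound 3 (2.22 log units; beyond the scatter) and an at least 14-fold lower number from compound 2 to compound 3 (1.14 log units; beyond the scatter), both large. Compound 4 keeps a six-membered aromatic ring there, as compound 3 does, so a step of that size is not expected. The expected change is small and upward, an at least 1.5-fold higher number from compound 3 to compound 4 (0.17 log units; that floor lies within the scatter). The estimate for compound 4 is 1500 nM, with an expected range from 500 nM to 6000 nM.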

Compound 4, solubility: 349000 nM
For compound 4 the middle estimate is 230-fold (2.37 log units) below the measured one, outside the stated range (above it).
By their numbers in this assay, from the lowest: compound 2; then compound 1; then compound 4. At a limit, below all of these: compound 3.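

In this assay, going by these compounds alone, the earlier compounds left phenyl at the low end, but one ring nitrogen in the group on this aromatic carbon reverses that, with an at least 340-fold higher number from compound 3 to compound 4 (2.54 log units; beyond the scatter). That step is only a floor: the limit of < 1000 nM in this assay, at which 1 of the 4 values shown sits.

Pyridin-2-yl also exceeds both earlier groups, with a 25-fold higher number from compound 2 to compound 4 (1.40 log units; beyond the scatter) and with a 2.1-fold higher number from compound 1 to compound 4 (0.32 log units; beyond the scatter), so a six-membered aromatic ring at this position does not by itself go with the low end.

As far as these compounds go, what pyridin-3-yl or pyridin-4-yl would give on this carbon stays open, and so does the effect of a pyrimidin-2-yl group.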